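The source may hold more compounds than are shown below. What is called first, only, known or untested is meant among the compounds shown, and "the series" means these compounds.

Series notes. Compound 1 `Cc1nc2cc(-c3ccccc3)nn2c(-c2cc(F)c3c(c2C)CCCO3)c1C(OC(C)(C)C)C(=O)O` in an ADME assay for permeability, using PAMPA, with a stated time of 4 h, at pH 7.4, tested at 100 uM (a higher number here means that the compound crosses the layer faster, a lower number that the compound crosses the layer more slowly), gives 218 nm/s; the only comparator so far, compound 2 `Cc1nc2cc(-c3ccc(OCc4ccccc4)cc3)nn2c(-c2cc(F)c3c(c2C)CCCO3)c1C(OC(C)(C)C)C(=O)O`, gives 313 nm/s, a number within the scatter of that of compound 1. Among the compounds with values here, the sole measured step, a 1.4-fold higher number from compound 1 to compound 2 (0.16 log units; within the scatter), is the one precedent that bears here. Compound 3 `Cc1nc2cc(-c3cccc(Oc4ccccc4)c3)nn2c(-c2cc(F)c3c(c2C)CCCO3)c1C(OC(C)(C)C)C(=O)O` differs from compound 1 by phenoxy in place of hydrogen on an aromatic carbon. Within the data shown here, with only a single step within the scatter to go on, no step beyond the scatter is expected in this assay from compound 1 to compound 3, and the expected change is a 1.2-fold higher number from compound 1 to compound 3 (0.09 log units; within the scatter). Compound 3 is therefore estimated at 270 nm/s, with a range from 160 nm/s to 450 nm/s.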

Compound 3, apparent permeability: 472 nm/s
Estimate against measurement, compound 3: 1.7-fold (0.24 log units) below, and the stated range ends below it.
By their numbers in this assay, from the lowest: compounds 1, 2 and 3 (each within the scatter of the next, the first and the last beyond it).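

A phenoxy group, meta to a large group, gives the only step beyond the scatter among the compounds shown, with a 2.2-fold higher number from compound 1 to compound 3 (0.34 log units; beyond the scatter) in this assay. This position therefore carries a large aryl ether with no loss in the read-out, and the change moves the number modestly upward. No measurement at hand accounts for this step. Still open, going by these compounds, is whether the number follows the phenoxy ring itself or the ether oxygen, and whether a methoxy group or a primary amine at this place moves it the same way.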